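A few compounds are considered here, and "the series" means these few. Any claim that something is new, unique, unknown or untested is made for them only; others in the source may bear on it.

Compound 1 `COc1cc(-c2nnc3c(OC4CCC4)cc(-c4ccc5[nH]ccc5c4)cn23)cc(OC)c1OC`: 694 nM
Compound 2 `COc1cc(-c2nnc3c(OC)cc(-c4ccc5c(ccn5C)c4)cn23)cc(OC)c1OC`: 33 nM
Compound 3 `COc1cc(-c2nnc3c(OCC(F)(F)F)cc(-c4ccc5c(ccn5C)c4)cn23)cc(OC)c1OC`: 483 nM

In a functional assay on HCT-116 cells (Homo sapiens) for antiproliferative activity, read by MTT assay, with a stated time of 48 h (on this read-out lower numbers stand for stronger inhibition and higher numbers for weaker inhibition), compound 3 gives 483 nM, which lies within the usual scatter of compound 1 and far from compound 2. Compound 4 `COc1cc(-c2nnc3c(OC4CCC4)cc(-c4ccc5c(ccn5C)c4)cn23)cc(OC)c1OC` differs from compound 3 by one change, cyclobutyl in place of 2,2,2-trifluoroethyl on an oxygen on an aromatic ring. Among the compounds with values here, the only measured step at this oxygen is a 15-fold higher number from compound 2 to compound 3 (1.17 log units; beyond the scatter), so the group there can matter greatly, yet that step does not involve cyclobutyl and gives no direction. Compound 1, which differs elsewhere but also carries cyclobutyl there, gives 694 nM. No shift beyond the scatter is therefore expected in this assay. The expected change is a 1.2-fold lower number from compound 3 to compound 4 (0.08 log units; within the scatter). For compound 4 the estimated value is 400 nM, within a range of 120 nM to 1200 nM.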

Compound 4, half-maximal inhibitory concentration: 750 nM
Beside the measured number, compound 4's estimate is 1.9-fold (0.27 log units) below it; the range from low to high includes it.
By their numbers in this assay, from the lowest: compound 2; then compounds 3, 1 and 4 (each within the scatter of the next).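

Cyclobutyl in place of methyl on the oxygen gives a 23-fold higher number from compound 2 to compound 4 (1.36 log units; beyond the scatter) in this assay, a large loss of activity. Cyclobutyl in place of 2,2,2-trifluoroethyl gives only a 1.6-fold higher number from compound 3 to compound 4 (0.19 log units; within the scatter) and stays within the scatter, so these two groups cannot be told apart here and both sit far from methyl. With cyclobutyl on the oxygen, methyl in place of hydrogen on the aromatic nitrogen also stays within the scatter, with a 1.1-fold higher number from compound 1 to compound 4 (0.03 log units; within the scatter) as the step.

No measurement here explains these results.

On these data alone, whether an ethyl group or a longer chain ending in an amine on this oxygen would keep the activity of compound 2 remains open.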